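A Small Change at a Double-Bonded Nitrogen

The compounds below may be only part of what the source reports. "The series", "measured", "known", "first", "only" and "open" are said of these compounds alone.

Of the compounds shown here, two have so far been tested in a functional assay for inhibition of beta-glucuronidase (Bos taurus), tested at 0.1 mM; a lower number here means a weaker effect, a higher number a stronger effect of the compound at the concentration tested. Compound 1 `CN/N=C/c1ccc2ccc(=O)oc2c1` gives 6.9%, the higher of the two numbers, and compound 2 `O=c1ccc2ccc(/C=N/N=C/c3ccc4ccc(=O)oc4c3)cc2o1` gives 2.3%; these two values lie within the scatter of each other, so neither can be called the stronger. Both numbers are small, meaning that at the tested concentration neither compound holds back much of the enzyme.

Compound 3 `O=c1ccc2ccc(/C=N/c3ccccc3)cc2o1` has not been measured. It differs from compound 1 in one place: phenyl in place of methylamino on a double-bonded nitrogen. Among the compounds with values here, no step between two measured compounds shows what such a change does here, so the expectation rests on the low numbers of compound 1 and compound 2 alone. The step of a number 1.1 percentage points higher from compound 1 to compound 3 (within the scatter) is expected to be small, with no direction beyond the scatter. Compound 3 is therefore estimated at 8%, in a range from 0% to 25%.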

Compound 3, a percentage reported as inhibition, at one concentration (the size of the read-out at that concentration, not a potency): 26.1%
For compound 3 the middle estimate is 18.1 percentage points below the measured one, and the stated range ends below it.
By their numbers in this assay, from the lowest: compounds 2 and 1 (each within the scatter of the next); then compound 3.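

In this assay, within the data shown here, putting phenyl in place of methylamino on a double-bonded nitrogen gives a number 19.2 percentage points higher from compound 1 to compound 3 (beyond the scatter), the first step here between measured compounds that differ in one place. Among these compounds, it shows that the read-out can respond to the group at this position, which the two low numbers of the earlier compounds could not show. Nothing available here explains the rise.

This single step changes several things together: a six-membered aromatic ring enters, while a hydrogen-bond donor and a hydrogen-bond acceptor leave, so it cannot tell which of these matters. Cyclohexyl would test whether the ring needs to be aromatic, while benzyl or a phenyl carrying a methoxy group or a carboxylic acid would show how far the result depends on the exact group at this position.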